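Indol-2-yl swap and microsomal clearance

The source may report more compounds than this note shows. Statements on the series, on what has been measured and on what is new or still open speak of the compounds shown alone.

In an ADME assay (liver) for metabolic stability, with Liver microsome (Rattus norvegicus) as the target, using microsomes and NADPH, with a stated time of 30 min, tested at 1 uM (on this read-out higher numbers stand for fast clearance and lower numbers for slow clearance), compound 1 `Nc1ccc(S(=O)(=O)N2CCN(c3ncc(C(O)(C(F)(F)F)C(F)(F)F)cc3C#CCCO)CC2)cn1` gives 68 mL.min-1.g-1 and compound 2 `Nc1ccc(S(=O)(=O)N2CCN(c3ncc(C(O)(C(F)(F)F)C(F)(F)F)cc3-c3ccc4c(c3)CC(=O)N4)CC2)cn1` gives 119 mL.min-1.g-1 while compound 3 `Nc1ccc(S(=O)(=O)N2CCN(c3ncc(C(O)(C(F)(F)F)C(F)(F)F)cc3-c3ccc4[nH]ncc4c3)CC2)cn1` gives 88 mL.min-1.g-1 in the same test. Compound 3 therefore stands within the scatter of both other values. Compound 4 `Nc1ccc(S(=O)(=O)N2CCN(c3ncc(C(O)(C(F)(F)F)C(F)(F)F)cc3-c3cc4ccccc4[nH]3)CC2)cn1` brings the change 1H-indol-2-yl in place of 1H-indazol-5-yl on an aromatic carbon with 1H-indol-2-yl in place of 1H-indazol-5-yl. Among the measured compounds shown here, no measured compound carries that group. The nearest precedent is the exchange of one two-ring group for another, a 1.4-fold lower number from compound 2 to compound 3 (0.13 log units; within the scatter) as shown. Even a 1.3-fold higher number from compound 1 to compound 3 (0.11 log units; within the scatter) and a 1.8-fold higher number from compound 1 to compound 2 (0.24 log units; within the scatter) stay within the scatter. The expected step is a 1.1-fold higher number from compound 3 to compound 4 (0.03 log units; within the scatter) and thus none beyond the scatter. For compound 4 95 mL.min-1.g-1 is expected, with an estimated range of 55 mL.min-1.g-1 to 165 mL.min-1.g-1 for the measurement.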

Compound 4, intrinsic clearance in microsomes: 146 mL.min-1.g-1
The estimate for compound 4 lay 1.5-fold (0.19 log units) below the measured number; measured number inside the range.
By their numbers in this assay, from the lowest: compounds 1, 3, 2 and 4 (each within the scatter of the next, the first and the last beyond it).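

In this assay, among the compounds shown here, 1H-indol-2-yl in place of 4-hydroxybut-1-yn-1-yl gives a 2.1-fold higher number from compound 1 to compound 4 (0.33 log units; beyond the scatter), the first step at this position, ortho to a large group, to pass the scatter, though only modestly. The steps of a 1.7-fold higher number from compound 3 to compound 4 (0.22 log units; within the scatter) and a 1.2-fold higher number from compound 2 to compound 4 (0.09 log units; within the scatter) stay within it, so these three two-ring groups are not separated on this read-out. No measurement shown bears on the reason for these steps.

Still open, as far as these compounds go, is how an amine or a carboxylic acid at this position would read. Also open, from the compounds shown here alone, is whether any group there gives a number clearly lower than that of compound 1.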